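Weak inhibitors of a lysosomal glucosidase, one substituent swapped

A few compounds are considered here, and "the series" means these few. Any claim that something is new, unique, unknown or untested is made for them only; others in the source may bear on it.

Among the measured compounds shown here, compound 1 `Cc1ccc(S(=O)(=O)Nc2ccc3c(c2)C(=O)N(Cc2ccccc2F)C3=O)cc1` is one of three compounds measured in an assay on isolated protein for inhibition of lysosomal alpha-glucosidase (Rattus norvegicus), read by colorimetric assay; a lower number here means a stronger inhibitor, a higher number a weaker inhibitor. In this assay compound 1 gives 195000 nM, the highest of the two numbers recorded. Compound 3 `O=C1c2ccc([N+](=O)[O-])cc2C(=O)N1CCNc1ccccc1` gives 111000 nM, which lies within the scatter of the number for compound 1. Compound 2 `Cc1ccc(S(=O)(=O)Nc2ccc3c(c2)C(=O)N(C)C3=O)cc1` reaches only the limit of the assay, > 200000 nM, so no number is known for it. For the measured compounds named here, the single step recorded between measured compounds, an at least 1.0-fold higher number from compound 1 to compound 2 (0.01 log units; that floor lies within the scatter), therefore ends at that limit of > 200000 nM in this assay, at which 1 of the 3 values shown sits, and says only that removing the group did not make the inhibitor stronger by anything beyond the scatter.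

The new compound 4 `Cc1ccc(S(=O)(=O)Nc2ccc3c(c2)C(=O)N(CCOc2cccc(O)c2)C3=O)cc1` differs from compound 1 in that same place: (3-hydroxyphenoxy)methyl in place of 2-fluorophenyl on a saturated chain carbon bound to an amide-type nitrogen in a ring. Going by the values given here, the one measured step at this position gave no change beyond the scatter, so the expectation for compound 4 is a number close to that of compound 1, with a real chance that the assay again reports only its limit. Compound 4 is estimated at 180000 nM, with a range from 60000 nM to 400000 nM. That estimate means a step of a 1.1-fold lower number from compound 1 to compound 4 (0.03 log units; within the scatter), which is expected to stay within the scatter.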

Compound 4, half-maximal inhibitory concentration: 55600 nM
The estimate for compound 4 lay 3.2-fold (0.51 log units) above the measured number; the measured number lies below the stated range.
By their numbers in this assay, from the lowest: compounds 4, 3 and 1 (each within the scatter of the next, the first and the last beyond it). At a limit, above all of these: compound 2.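

The change from 2-fluorobenzyl to 2-(3-hydroxyphenoxy)ethyl gives a 3.5-fold lower number from compound 1 to compound 4 (0.54 log units; beyond the scatter), so this position, where the earlier step had shown nothing beyond the scatter, can in fact move the number in this assay. Set against the hydrogen on the same atom, the (3-hydroxyphenoxy)methyl group gives an at least 3.5-fold lower number from compound 2 to compound 4 (0.55 log units; beyond the scatter), the second step at this position to pass beyond the scatter. Compound 2 is known only as a limit, so this second step is a floor and its true size stays unknown: the limit of > 200000 nM in this assay, at which 1 of the 4 values shown sits.

The entering group differs from 2-fluorophenyl in several ways at once, with an ether oxygen and a hydroxyl gained and the fluorine lost, and the compounds shown do not tell which of these changes carries the step. From the compounds shown here alone, a plain 2-phenoxyethyl group, a 2-(3-methoxyphenoxy)ethyl group or an amine nitrogen in place of the ether oxygen would pull these changes apart, and whether a still longer chain on this nitrogen moves the number further also stays open.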